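This account rests on a few compounds, and the source may have more. Where it says the series, first, only, none or still open, it means among the compounds named here.

Compound 1, `Cc1nc(N)c2c(-c3cccs3)cn([C@@H]3O[C@H](CO)[C@@H](O)[C@H]3O)c2n1`, and compound 2, `Cc1nc(N)c2c(-c3cc4ccccc4o3)cn([C@@H]3O[C@H](CO)[C@@H](O)[C@H]3O)c2n1`, share one core and differ only in the group carried on the five-membered ring of that core. In a functional assay on K562 cells (Homo sapiens), read by MTT assay, with a stated time of 72 h (a lower number here means a stronger inhibitor, a higher number a weaker inhibitor), compound 1 gives > 20000 nM, which is a limit of the assay rather than a number. Compound 2 gives 15700 nM in this assay. The change between them is 1-benzofuran-2-yl in place of thiophen-2-yl on an aromatic carbon, and it made a step of an at least 1.2-fold lower number from compound 1 to compound 2 (0.10 log units; that floor lies within the scatter), a size that cannot be read as more than the floor set by the limit of > 20000 nM in this assay, at which 2 of the 3 values shown sit.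

Compound 3, `CN(C)c1ncnc2c1c(-c1cccs1)cn2[C@@H]1O[C@H](CO)[C@@H](O)[C@H]1O`, carries a different core; the difference between the two cores is not broken down here. Compound 3 gives > 20000 nM in this assay, again a limit and not a number. Compound 4, `CN(C)c1ncnc2c1c(-c1cc3ccccc3o1)cn2[C@@H]1O[C@H](CO)[C@@H](O)[C@H]1O`, stands to compound 3 as compound 2 stands to compound 1: the change is 1-benzofuran-2-yl in place of thiophen-2-yl on an aromatic carbon, at a place described in the same words as for the first pair.

Among the measured compounds shown here, with only the floor of the first step to go by, the expectation for compound 4 is a step of an at least 1.1-fold lower number from compound 3 to compound 4 (0.04 log units; that floor lies within the scatter), resting on compound 1 at > 20000 nM moving to compound 2 at 15700 nM. Compound 4 is therefore estimated at 18000 nM in this assay, expected to lie between 8000 nM and 40000 nM, with a real chance that only a limit is reported.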

Compound 4, half-maximal inhibitory concentration: > 20000 nM
Compound 4: only a limit was reported; the forecaster's own chance of this, stated with the estimate: 55%; middle value at least 1.1-fold (0.04 log units) from the limit.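

In this assay compound 4 gives > 20000 nM, which is a limit and not a number. Compound 3 also stands at a limit, so no size can be read for the step between compound 3 and compound 4. The compounds shown leave open whether 1-benzofuran-2-yl in place of thiophen-2-yl changes the number at all on the core of compound 3, and the result rests on this: the limit of > 20000 nM in this assay, at which 3 of the 4 values shown sit.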